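The compounds below may be only part of what the source reports. "The series", "measured", "known", "first", "only" and "open" are said of these compounds alone.

Compounds measured so far:
- compound 1, `CC(C)n1c(SCc2ccccc2Cl)nc2cc(NC(=O)C3CC3)ccc21`: 6300 nM
- compound 2, `COc1ccc(C#N)cc1CSc1nc2cc(NC(=O)C3CC3)ccc2n1C(C)C`: 570 nM
- compound 3, `CCCCCn1c(SCc2cc([N+](=O)[O-])ccc2OC)nc2cc(NC(=O)NC(C)(C)C)ccc21`: 210 nM

All three were tested in an assay on isolated protein for inhibition of Gonadotropin-releasing hormone receptor (Homo sapiens); a lower number here means a stronger inhibitor, a higher number a weaker inhibitor. Compound 3 gives the lowest number of the three, 210 nM, and since its gaps to compound 2 and to compound 1 both lie beyond the usual scatter, it is the strongest inhibitor of the set. Going by the values given here, the one change that has been measured one piece at a time is an 11-fold lower number from compound 1 to compound 2 (1.04 log units; beyond the scatter), which is a large step; it concerns the aryl group on the saturated carbon bound to the sulfur.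

Compound 4, `COc1ccc([N+](=O)[O-])cc1CSc1nc2cc(NC(=O)NC(C)(C)C)ccc2n1Cc1cccnc1`, differs from compound 3 elsewhere: pyridin-3-yl in place of butyl on a saturated chain carbon bound to an aromatic nitrogen. Among the compounds with values here, no measured pair here varies the group on the saturated carbon bound to the aromatic nitrogen; compounds 1, 2 and 3 carry only chains at that position, so the known steps do not bear on this change. With nothing to lean on, the expectation is a step of modest size, a 1.4-fold lower number from compound 3 to compound 4 (0.15 log units; within the scatter), in either direction. Compound 4 is therefore estimated at 150 nM, with a likely range from 40 nM to 600 nM.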

Compound 4, half-maximal inhibitory concentration: 33 nM
Estimate against measurement, compound 4: 4.5-fold (0.66 log units) above; the measured number lies below the stated range.
By their numbers in this assay, from the lowest: compound 4; then compound 3; then compound 2; then compound 1.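

In this assay, the group on the saturated chain carbon bound to an aromatic nitrogen proves able to shift the result: going from pentyl to (pyridin-3-yl)methyl gives a 6.4-fold lower number from compound 3 to compound 4 (0.80 log units; beyond the scatter). The earlier compounds shown here carried only chains at this position, so they could not show that an aromatic ring with a hydrogen-bond acceptor is accepted there, or that the compound can end up a stronger inhibitor with it. No measurement at hand gives a reason for this step, and a single pair cannot say whether the ring itself, its nitrogen or simply the larger group accounts for it.

What the compounds shown leave open is how far the result depends on that nitrogen, which a plain phenyl ring in place of pyridin-3-yl would help to settle, and whether a longer chain ending in an amine would serve as well. From the compounds shown here alone, it also remains open whether the same change would give a similar step in a compound with the cyclopropyl amide of compound 2, since this pair carries only the tert-butyl urea.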